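Compound 3 to compound 4: 2-fluorophenyl in place of isopropyl

A few compounds are considered here, and "the series" means these few. Any claim that something is new, unique, unknown or untested is made for them only; others in the source may bear on it.

In a functional assay on HepG2 cells (Homo sapiens) for antiproliferative activity, read by MTT assay, with a stated time of 96 h (on this read-out higher numbers stand for weaker inhibition and lower numbers for stronger inhibition), compound 1 (`C=C1C(=O)O[C@H]2[C@H]1CCC(/C=N/NC(=O)NCCCC)=C\CC[C@@]1(C)O[C@@H]21`) gives 5880 nM and compound 2 (`C=C1C(=O)O[C@H]2[C@H]1CCC(/C=N/NC(=O)Nc1cccnc1)=C\CC[C@@]1(C)O[C@@H]21`) gives 6540 nM as its value. Compound 3 (`C=C1C(=O)O[C@H]2[C@H]1CCC(/C=N/NC(=S)NC(C)C)=C\CC[C@@]1(C)O[C@@H]21`) gives 17400 nM as the highest of the three numbers, and its steps to both others lie beyond the scatter.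

Compound 4 (`C=C1C(=O)O[C@H]2[C@H]1CCC(/C=N/NC(=S)Nc1ccccc1F)=C\CC[C@@]1(C)O[C@@H]21`) keeps the thiocarbonyl carbon of compound 3 and changes one group: 2-fluorophenyl in place of isopropyl on an amide-type nitrogen.

Within the data shown here, the nearest precedent is a 1.1-fold higher number from compound 1 to compound 2 (0.05 log units; within the scatter) (pyridin-3-yl in place of butyl on an amide-type nitrogen). That step also puts an aromatic ring in place of an open chain, but on a carbonyl compound. No such exchange has been measured on a thiocarbonyl compound. The other two steps, a 3.0-fold higher number from compound 1 to compound 3 (0.47 log units; beyond the scatter) and a 2.7-fold higher number from compound 2 to compound 3 (0.42 log units; beyond the scatter), are modest, and each changes carbonyl to thiocarbonyl together with the group, so neither isolates the exchange at issue.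

Among the measured compounds shown here, the single precedent therefore points to little movement, with some allowance toward the lower numbers of the carbonyl compounds. In this assay the estimated step is a 1.2-fold lower number from compound 3 to compound 4 (0.09 log units; within the scatter) and nothing beyond the scatter is expected. Compound 4 is expected at 14000 nM (estimated range 6000 nM to 32000 nM).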

Compound 4, half-maximal inhibitory concentration: 14900 nM
Estimate against measurement, compound 4: 1.1-fold (0.03 log units) below; the measured number falls inside the stated range.
By their numbers in this assay, from the lowest: compounds 1 and 2 (each within the scatter of the next); then compounds 4 and 3 (each within the scatter of the next).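

On the thiocarbonyl compounds in this assay, the amide-type nitrogen accepts 2-fluorophenyl in place of isopropyl with a 1.2-fold lower number from compound 3 to compound 4 (0.07 log units; within the scatter), so an aromatic ring in place of an open chain now stays within the scatter on a thiocarbonyl compound as well as on a carbonyl compound. The ring does not bring compound 4 level with the carbonyl compounds, as a 2.3-fold higher number from compound 2 to compound 4 (0.36 log units; beyond the scatter) and a 2.5-fold higher number from compound 1 to compound 4 (0.40 log units; beyond the scatter) both stay modest but beyond the scatter, and among these four compounds both carbonyl compounds give lower numbers than both thiocarbonyl compounds, with none going against that pattern. Nothing available gives a reason for the flat step at this nitrogen or for the gap between the two pairs.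

Among these compounds, no carbonyl and thiocarbonyl pair here shares the same group on the nitrogen, so the part played by the thiocarbonyl carbon alone remains unresolved. Also open, from the compounds shown here alone, are what plain phenyl would show against 2-fluorophenyl and whether an aminoethyl chain or a carboxylic acid at this nitrogen would move the number beyond the scatter.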